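Swapping the halogenated aryl on a thiosemicarbazone

The source may hold more compounds than are shown below. What is called first, only, known or untested is meant among the compounds shown, and "the series" means these compounds.

Compound 1, `Fc1cccc(NC(=S)N/N=C/c2ccc3ccccc3n2)c1`: 79900 nM in a functional assay on SGC-7901 cells (Homo sapiens) for antiproliferative activity, read by sulforhodamine B assay, with a stated time of 72 h; a higher number here means a weaker inhibitor, a lower number a stronger inhibitor.
Compound 2, `NC(=S)N/N=C/c1cc2ccccc2s1`: a limit of > 100000 nM in this assay.
Compound 3, `FC(F)(F)c1ccccc1NC(=S)N/N=C/c1ccc2ccccc2n1`: 20700 nM in this assay.

Of the two numbers given, compound 1 stands highest, and compound 3 sits at the lower number, a gap beyond the scatter. Compound 2 reports only a limit (the limit of > 100000 nM in this assay, at which 1 of the 3 values shown sits). Compound 4, `S=C(N/N=C/c1ccc2ccccc2n1)Nc1ccc(Cl)cc1`, differs from compound 1 in one place: 4-chlorophenyl in place of 3-fluorophenyl on an amide-type nitrogen. Going by the values given here, no measured pair isolates this exchange. The step of a 1.8-fold lower number from compound 1 to compound 4 (0.25 log units; within the scatter) is expected to be a small lowering, at or just beyond the scatter. For compound 4 in this assay the estimate is 45000 nM, with a range from 15000 nM to 100000 nM.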

Compound 4, half-maximal inhibitory concentration: 87600 nM
The estimate for compound 4 lay 1.9-fold (0.29 log units) below the measured number; the range from low to high includes it.
By their numbers in this assay, from the lowest: compound 3; then compounds 1 and 4 (each within the scatter of the next). At a limit, above all of these: compound 2.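

In this assay, the exchange of 3-fluorophenyl for 4-chlorophenyl on the amide-type nitrogen gives a 1.1-fold higher number from compound 1 to compound 4 (0.04 log units; within the scatter), so the two compounds stand level. Going by these compounds alone, this is the only measured pair that isolates a change at this position, and it shows that this one halogenated aryl can replace the other with no step beyond the scatter. Nothing measured here accounts for this step. From the compounds shown here alone, whether an amine or a carboxylic acid on the aryl ring, or a longer chain in its place, would shift the number remains open.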